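Dropping the Imidazolylmethyl Group: Compound 3 Estimated

The source may report more compounds than this note shows. Statements on the series, on what has been measured and on what is new or still open speak of the compounds shown alone.

Compound 1 `CCOC(=O)c1sc2ccc(NCc3c[nH]cn3)cc2c1NC(=O)c1cc(OC)c(OC)c(OC)c1`: 6790 nM
Compound 2 `CCOC(=O)c1sc2ccc(NCc3nc[nH]c3C)cc2c1NC(=O)c1cc(OC)c(OC)c(OC)c1`: 2230 nM

In a functional assay on HeLa cells (Homo sapiens) for antiproliferative activity, read by MTT assay, with a stated time of 48 h (a higher number here means a weaker inhibitor of growth, a lower number a stronger inhibitor of growth), compound 2 stands at the lowest of the two numbers, set apart from compound 1 by the step of a 3.0-fold lower number from compound 1 to compound 2 (0.48 log units; beyond the scatter). Compound 3 `CCOC(=O)c1sc2ccc(N)cc2c1NC(=O)c1cc(OC)c(OC)c(OC)c1` differs from compound 2 by hydrogen in place of (5-methyl-1H-imidazol-4-yl)methyl on a nitrogen on an aromatic ring. Going by the values given here, no measured step removes this group; the single step measured, a methyl added on the imidazole, does not bear directly on its loss. Among the compounds with values here, with no comparable step, compound 3 is expected to give a higher number, the step of a 4.5-fold higher number from compound 2 to compound 3 (0.65 log units; beyond the scatter) being an estimate of wide uncertainty. Compound 3 is estimated at 10000 nM, within 2000 nM to 50000 nM.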

Compound 3, concentration for 50% growth inhibition: 4660 nM
The estimate for compound 3 lay 2.1-fold (0.33 log units) above the measured number; the measured number falls inside the stated range.
By their numbers in this assay, from the lowest: compound 2; then compounds 3 and 1 (each within the scatter of the next).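

On a nitrogen on an aromatic ring, the plain amino compound 3 still inhibits growth in this assay, so the imidazole-bearing group is not needed for this activity. Only the methylated group gives a gain beyond the scatter (a 2.1-fold higher number from compound 2 to compound 3 (0.32 log units; beyond the scatter)), whereas the unmethylated group gives no clear difference (a 1.5-fold lower number from compound 1 to compound 3 (0.16 log units; within the scatter)). Nothing available explains these steps.

The compounds shown leave open whether a different group on this nitrogen, such as a benzyl group, an acetyl group or a longer alkyl chain, would change growth inhibition further. They also leave open whether an ethyl group in place of the imidazole methyl would extend the gain.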